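The source may report more compounds than this note shows. Statements on the series, on what has been measured and on what is new or still open speak of the compounds shown alone.

The series shares the core of compound 1 `C=CCOc1nc(N)nc2c1ncn2/C=C1/CC1(CO)CO` and is read in an ADME assay on MOLT-3 cells (Homo sapiens) for cytotoxicity, with a stated time of 7 days; on this read-out higher numbers stand for lower toxicity in this test and lower numbers for higher toxicity in this test. Compound 1 gives > 20000 nM, which is a limit of the assay. Compound 2 `CCCCCCCCOc1nc(N)nc2c1ncn2/C=C1/CC1(CO)CO` gives > 20000 nM, again a limit. The step that the two limits leave unreadable from compound 1 to compound 2 is thus unreadable, and the whole weight of the series rests on (the limit of > 20000 nM in this assay, at which 2 of the 3 values shown sit). Compound 3 `CCCNc1nc(N)nc2c1ncn2/C=C1/CC1(CO)CO` carries "not determined" (no result reported) and so stands without a number in this series. Compound 4 `Nc1nc(SC2CCCC2)c2ncn(/C=C3/CC3(CO)CO)c2n1` differs from compound 3 by cyclopentylsulfanyl in place of propylamino on an aromatic carbon. Among the compounds with values here, no measured step bears on this change; the only recorded step cannot be sized. With both determined values sitting at the limit, no movement beyond the scatter is expected. Compound 4 is expected to give 30000 nM, most likely again as a limit, within 10000 nM to 100000 nM.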

Compound 4, half-maximal cytotoxic concentration: > 20000 nM
Compound 4: no number, only a limit; the forecaster's own chance of this, stated with the estimate: 80%; the middle value is on the limit's open side.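

No new step can be read: the steps from compound 1 and compound 2 to compound 4 join limits only and cannot be sized. The compounds shown leave open whether changing the group on the aromatic carbon alters cytotoxicity at all.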